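The source may hold more compounds than are shown below. What is called first, only, known or untested is meant among the compounds shown, and "the series" means these compounds.

Within the data shown here, in a functional assay on CHO-K1 cells for antagonist activity at transient receptor potential cation channel subfamily V member 1 (Homo sapiens), read by FLIPR (a lower number here means a stronger inhibitor, a higher number a weaker inhibitor), compound 2 `COC1CCN(c2nc(C(F)(F)F)ccc2CNC(=O)C(C)c2ccc(NS(C)(=O)=O)c(F)c2)CC1` gives 2.4 nM, the higher of the two numbers measured so far, while compound 1 `CC(C(=O)NCc1ccc(C(F)(F)F)nc1N1CCC(Cc2cc(F)cc(F)c2)CC1)c1ccc(NS(C)(=O)=O)c(F)c1` gives 0.4 nM. Among the measured compounds shown here, the only measured change at this position is a 6.0-fold higher number from compound 1 to compound 2 (0.78 log units; beyond the scatter). Compound 3 `CC(C(=O)NCc1ccc(C(F)(F)F)nc1N1CCC(CN(C)C)CC1)c1ccc(NS(C)(=O)=O)c(F)c1` carries (dimethylamino)methyl in place of methoxy on a saturated ring carbon. Because a 6.0-fold higher number from compound 1 to compound 2 (0.78 log units; beyond the scatter) was only modest, a step of similar or smaller size is expected here in this assay, more likely toward a higher number than a lower one. The expected step is a 2.1-fold higher number from compound 2 to compound 3 (0.32 log units; beyond the scatter). Compound 3 is therefore estimated at 5 nM, with a likely range from 1.5 nM to 20 nM.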

Compound 3, inhibition constant: 2.1 nM
Compound 3: the middle estimate sits 2.4-fold (0.38 log units) above what was measured, and the stated range covers the measured number.
By their numbers in this assay, from the lowest: compound 1; then compounds 3 and 2 (each within the scatter of the next).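

In this assay, (dimethylamino)methyl in place of methoxy on this saturated ring carbon gives a 1.1-fold lower number from compound 2 to compound 3 (0.06 log units; within the scatter), so the two groups cannot be told apart here. Against the 3,5-difluorobenzyl group, the same (dimethylamino)methyl group gives a 5.3-fold higher number from compound 1 to compound 3 (0.72 log units; beyond the scatter), which leaves compound 1 alone standing apart from the other two. No evidence bears on what lies behind these numbers.

From the compounds shown here alone, it remains open whether a benzyl group without fluorine, a carboxylic acid or a longer chain of carbons at this ring carbon would read like compound 1 or like compound 2 and compound 3.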